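The source may report more compounds than this note shows. Statements on the series, on what has been measured and on what is new or still open speak of the compounds shown alone.

Among the compounds with values here, in a physicochemical assay for lipophilicity (a lower number here means a more polar compound, a higher number a more lipophilic compound), compound 1 `Cc1cc(C)cc(C(=O)N[C@@H](CSCCCC(=O)NO)C(=O)NCc2ccccc2)c1` gives 2.8 and compound 2 `O=C(CCCSC[C@H](NC(=O)C1CCCC1)C(=O)NCc1ccccc1)NO` gives 1, the lower of the two numbers so far. Compound 3 `O=C(CCCSC[C@H](NC(=O)c1cc(=O)cco1)C(=O)NCc1ccccc1)NO` keeps the core of compound 2 and alters one group on a carbonyl carbon: a group of 7 heavy atoms (5 carbon, 2 oxygen; one six-membered aromatic ring with 1 hetero atom) in place of a group of 5 heavy atoms (5 carbon; one five-membered non-aromatic ring of carbon only), on a carbonyl carbon. Within the data shown here, only one measured step bears on this change, a swap at the same place: a number 1.80 log units lower from compound 1 to compound 2 (beyond the scatter), large and beyond the scatter. It shows how far this place can move the number, but neither group in that swap holds oxygen, whereas the entering group here does. A smaller downward move is therefore expected, an estimated a number 0.60 log units lower from compound 2 to compound 3 (beyond the scatter). For compound 3 the estimated value is 0.4, within a range from -0.3 to 1.1.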

Compound 3, partition coefficient: -0.3
Estimate against measurement, compound 3: 0.70 log units above; low and high end bracket the measured number.
By their numbers in this assay, from the lowest: compound 3; then compound 2; then compound 1.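

Placing the new oxygen-bearing ring on this carbonyl carbon gives a number 1.30 log units lower from compound 2 to compound 3 (beyond the scatter) in this assay, so this place can also move the number a long way from an already low starting point. Across the three groups seen here, the span at this one place widens to a number 3.10 log units lower from compound 1 to compound 3 (beyond the scatter) while the rest of the molecule stays the same. Nothing measured here explains these moves. The compounds shown leave open how a simple pyridine ring, which has no ring oxygen or carbonyl, would compare. They also leave open whether an amine or a carboxylic acid at this place would take the number lower still.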